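From compound 2 to compound 4: pyridyl for bromophenyl

The source may report more compounds than this note shows. Statements on the series, on what has been measured and on what is new or still open speak of the compounds shown alone.

The measured compounds, with their numbers in a functional assay on 1321-N1 cells for agonist activity at P2Y purinoceptor 6 (Homo sapiens), read by scintillation counting and inositol phosphate accumulation; a lower number here means that less compound is needed, a higher number that more compound is needed for the effect:
compound 1 `O=c1[nH]/c(=N\OCCCCc2ccccc2)ccn1[C@@H]1O[C@H](COP(=O)(O)OP(=O)(O)OP(=O)(O)O)[C@@H](O)[C@H]1O`: 251 nM
compound 2 `O=c1[nH]/c(=N\OCCCc2ccc(Br)cc2)ccn1[C@@H]1O[C@H](COP(=O)(O)OP(=O)(O)OP(=O)(O)O)[C@@H](O)[C@H]1O`: 225 nM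
compound 3 `O=c1[nH]/c(=N\OCCCc2ccc([N+](=O)[O-])cc2)ccn1[C@@H]1O[C@H](COP(=O)(O)OP(=O)(O)OP(=O)(O)O)[C@@H](O)[C@H]1O`: 1330 nM

Compound 2 has the lowest number of the three. Its nearest neighbour is compound 1, with a 1.1-fold lower number from compound 1 to compound 2 (0.05 log units; within the scatter), so these two cannot be told apart. Compound 3 stands furthest away, with a 5.9-fold higher number from compound 2 to compound 3 (0.77 log units; beyond the scatter), a modest step. Compound 4 `O=c1[nH]/c(=N\OCCCc2cccnc2)ccn1[C@@H]1O[C@H](COP(=O)(O)OP(=O)(O)OP(=O)(O)O)[C@@H](O)[C@H]1O` is made from compound 2 by pyridin-3-yl in place of 4-bromophenyl on a saturated chain carbon, three bonds along the chain from an oxygen. Going by the values given here, two steps bear on this change: the exchange of bromo for hydrogen, a 1.1-fold lower number from compound 1 to compound 2 (0.05 log units; within the scatter), left the number unchanged, while the exchange of bromo for nitro, a 5.9-fold higher number from compound 2 to compound 3 (0.77 log units; beyond the scatter), and the related 5.3-fold higher number from compound 1 to compound 3 (0.72 log units; beyond the scatter) raised it modestly. A pyridin-3-yl is neither of these, so compound 4 is expected to land between them, a small rise in this assay, a 2.0-fold higher number from compound 2 to compound 4 (0.30 log units; within the scatter), that may still fall within the scatter. The estimate for compound 4 is 450 nM, with a range from 150 nM to 1500 nM.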

Compound 4, half-maximal effective concentration: 2950 nM
For compound 4 the middle estimate is 6.6-fold (0.82 log units) below the measured one; measured number above the stated range.
By their numbers in this assay, from the lowest: compounds 2 and 1 (each within the scatter of the next); then compound 3; then compound 4.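

In this assay, replacing the 4-bromophenyl ring with pyridin-3-yl gave a large step, a 13-fold higher number from compound 2 to compound 4 (1.12 log units; beyond the scatter), and the step from the 4-phenylbutyl compound was of similar size, a 12-fold higher number from compound 1 to compound 4 (1.07 log units; beyond the scatter). The earlier exchanges had shown only a modest rise with nitro, yet pyridin-3-yl went further than 4-nitrophenyl, a 2.2-fold higher number from compound 3 to compound 4 (0.35 log units; beyond the scatter), so a ring nitrogen in place of a substituted carbon ring cost more here than any exchange seen before at this place on the chain. Nothing measured here accounts for the size of this rise.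

Going by these compounds, it remains open whether the rise follows from the ring nitrogen itself or from the loss of the bromo, a question that a plain 3-phenylpropyl group on the same chain would help to settle. A pyridin-4-yl or pyridin-2-yl ring would show whether the place of the nitrogen in the ring matters.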